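The source may hold more compounds than are shown below. What is called first, only, known or untested is meant among the compounds shown, and "the series" means these compounds.

Measured compounds:
compound 1 `O=CCN1N=C(c2ccc3ccccc3c2)CC1c1cccc(Cl)c1Cl`; in a functional assay on IMR-32 cells (Homo sapiens) for cytotoxicity, read by sulforhodamine B assay, with a stated time of 48 h (a lower number here means a stronger inhibitor, a higher number a weaker inhibitor), compound 1 gives 16900 nM
compound 2 `COc1ccc(C2CC(c3ccc4ccccc4c3)=NN2CC=O)cc1O`; compound 2 gives 1490 nM
compound 3 `O=CCN1N=C(c2ccc3ccccc3c2)CC1c1cccc(Br)c1`; compound 3 gives 9870 nM

Compound 3 holds the second highest of the three numbers: the nearest step is a 1.7-fold lower number from compound 1 to compound 3 (0.23 log units; within the scatter), the furthest is a 6.6-fold higher number from compound 2 to compound 3 (0.82 log units; beyond the scatter).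

Compound 4 `COc1ccc(C2CC(c3ccc4ccccc4c3)=NN2CC=O)cc1` differs from compound 3 by 4-methoxyphenyl in place of 3-bromophenyl on a saturated ring carbon. Among the compounds with values here, two steps bear on this change: a 6.6-fold higher number from compound 2 to compound 3 (0.82 log units; beyond the scatter) and an 11-fold lower number from compound 1 to compound 2 (1.05 log units; beyond the scatter), both tied to the 3-hydroxy-4-methoxyphenyl. The 4-methoxyphenyl of compound 4 lacks the hydroxy of that group, so only part of that shift is expected, a modest lower number, a 2.8-fold lower number from compound 3 to compound 4 (0.45 log units; beyond the scatter). Compound 4 is estimated at 3500 nM, with a range of 1200 nM to 10000 nM.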

Compound 4, half-maximal inhibitory concentration: 4120 nM
Compound 4: the middle estimate sits 1.2-fold (0.07 log units) below what was measured; the measured number falls inside the stated range.
By their numbers in this assay, from the lowest: compound 2; then compound 4; then compounds 3 and 1 (each within the scatter of the next).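

In this assay, the hydroxy of the 3-hydroxy-4-methoxyphenyl now has its own measured share: hydrogen in its place gives a 2.8-fold higher number from compound 2 to compound 4 (0.44 log units; beyond the scatter). The 4-methoxyphenyl without that hydroxy still separates from both halogen-bearing aryl groups on the saturated ring carbon, with a 2.4-fold lower number from compound 3 to compound 4 (0.38 log units; beyond the scatter) and a 4.1-fold lower number from compound 1 to compound 4 (0.61 log units; beyond the scatter). No evidence is available to explain these steps.

Open, from the compounds shown here alone, is what a 3-hydroxyphenyl without the methoxy would give, or an amine in place of the methoxy. Also open, going by these compounds, is the effect of a longer chain in place of the formylmethyl group.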